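The source may hold more compounds than are shown below. What is called first, only, known or untested is meant among the compounds shown, and "the series" means these compounds.

Measured compounds:
- compound 1, `C#CCNC1CCc2c(SCc3cccc(C)c3)cccc21`: > 100000 nM
- compound 2, `C#CCNC1CCc2c(SCCc3cccc(C)c3)cccc21`: 4960 nM
- compound 3, `C#CCNC1CCc2c(SCCc3ccc(F)c(F)c3)cccc21`: "not determined" (no result reported)

In an ADME assay on isolated protein for inhibition of Amine oxidase [flavin-containing] B (Homo sapiens) (on this read-out higher numbers stand for weaker inhibition and lower numbers for stronger inhibition), compound 1 gives > 100000 nM, which is a limit of the assay and not a number. Compound 1 therefore sits at the limit of > 100000 nM in this assay, at which 1 of the 3 values shown sits, with no measured inhibition to anchor it. Among the measured compounds shown here, compound 2, which carries the longer chain to its aryl group, gives 4960 nM in this assay, the only single number in the set. Compound 3 has no result in this assay.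

The unmeasured compound 4, `C#CCNC1CCc2c(SCc3cccc(F)c3)cccc21`, differs from compound 1 by fluoro in place of methyl on an aromatic carbon. For the measured compounds named here, no pair of measured compounds shows a step of this kind, so no size can be read from the data for fluoro in place of methyl on an aromatic carbon. The expectation is that the step that the limit leaves unreadable from compound 1 to compound 4 stays within the scatter and that compound 4, like compound 1, is more likely to return a limit than a number in this assay. Compound 4 is estimated at 120000 nM, with a range from 30000 nM to 500000 nM.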

Compound 4, half-maximal inhibitory concentration: 11600 nM
Compound 4: the middle estimate sits 10-fold (1.01 log units) above what was measured; the whole stated range lies above it.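

In this assay, the position on the 3-methylphenyl ring, meta to a large group, proves responsive: fluoro in place of methyl gives an at least 8.6-fold lower number from compound 1 to compound 4 (0.93 log units; beyond the scatter). With this change, compound 4 gives a single number on the shorter chain, 11600 nM, so inhibition on that chain can now be read as a value. Compound 1 gives > 100000 nM, which is a limit of the assay and not a number, and the true size of the step stays unknown because of that limit: the limit of > 100000 nM in this assay, at which 1 of the 4 values shown sits.

Going by these compounds, whether chloro, methoxy or an amine at this position would follow fluoro or methyl remains open. Also open, on these data alone, is whether fluoro in place of methyl gives a comparable step on the longer chain of compound 2, at 4960 nM.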